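A few compounds are considered here, and "the series" means these few. Any claim that something is new, unique, unknown or untested is made for them only; others in the source may bear on it.

Measured compounds: compound 1 `Fc1cccc(Cl)c1-c1cc(-c2cnn(C3CCNCC3)c2)on1` gives 60% in an assay on a protein complex for positive allosteric modulation of Neuronal acetylcholine receptor; alpha4/beta2 (Homo sapiens); on this read-out higher numbers stand for larger maximal responses and lower numbers for smaller maximal responses; compound 2 `Fc1cccc(-c2cc(-c3cnn(C4CCNCC4)c3)on2)c1Cl` gives 47%. Compound 2 stands lowest of the two, and the step of a number 13 percentage points lower from compound 1 to compound 2 (beyond the scatter) is beyond the scatter.

Compound 3 `Cc1cc(-c2cnn(C3CCNCC3)c2)on1` is not yet measured. Its change from compound 2 is methyl in place of 2-chloro-3-fluorophenyl on an aromatic carbon. Among the measured compounds shown here, no measured step involves the loss of the whole aryl group; the only step in hand, a number 13 percentage points lower from compound 1 to compound 2 (beyond the scatter), concerns only the placement of the halogens on that ring, so it bears on this change indirectly at best. A further drop is expected, with wide uncertainty, as a number 17 percentage points lower from compound 2 to compound 3 (beyond the scatter). Compound 3 is therefore estimated at 30%, range 5% to 60%.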

Compound 3, largest response reached (reported as efficacy), in percent of the reference or control that the assay uses: 19%
The estimate for compound 3 lay 11 percentage points above the measured number, and the stated range covers the measured number.
By their numbers in this assay, from the lowest: compound 3; then compound 2; then compound 1.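

In this assay, methyl on this aromatic carbon next to the ring nitrogen stands below both halogenated phenyl compounds (a number 28 percentage points lower from compound 2 to compound 3 (beyond the scatter); a number 41 percentage points lower from compound 1 to compound 3 (beyond the scatter)). The position therefore responds to the loss of the whole aryl group, not only to where the halogens sit on it. Nothing on hand accounts for either step.

Open, as far as these compounds go, is whether unsubstituted phenyl, without either halogen, would keep the response of compound 1 or fall toward that of compound 3. Also open, from the compounds shown here alone, is how a longer alkyl chain, a cyclohexyl ring or an amine would read at this position.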